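Replacing the anilino group on a weakly cytotoxic core

The compounds below may be only part of what the source reports. "The series", "measured", "known", "first", "only" and "open" are said of these compounds alone.

Measured so far:
- compound 1, `Cc1cc(NC(C)C)nc(SCc2nc3ccccc3[nH]2)n1`, which in a functional assay on PC-3 cells (Homo sapiens) for cytotoxicity, read by MTT assay, with a stated time of 72 h (on this read-out higher numbers stand for weaker inhibition and lower numbers for stronger inhibition), gives only a limit, > 100000 nM.
- compound 2, `Cc1cc(Nc2ccc(Br)cc2)nc(SCc2nc3ccccc3[nH]2)n1`, which in this assay gives 37100 nM.

Compound 2 thus holds the only definite number shown; the other value is a limit (the limit of > 100000 nM in this assay, at which 1 of the 2 values shown sits). For the measured compounds named here, the single measured step, an at least 2.6-fold lower number from compound 1 to compound 2 (0.43 log units; beyond the scatter), shows that the group at this position matters. Compound 3, `Cc1cc(N(C)Cc2ccccc2)nc(SCc2nc3ccccc3[nH]2)n1`, differs from compound 2 by benzyl(methyl)amino in place of (4-bromophenyl)amino on an aromatic carbon. Going by the values given here, no measured step covers this exchange, so compound 3 is expected to stay close to compound 2, a 1.2-fold higher number from compound 2 to compound 3 (0.08 log units; within the scatter), within the scatter. The estimate for compound 3 is 45000 nM, between 15000 nM and 150000 nM.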

Compound 3, half-maximal inhibitory concentration: > 100000 nM
Compound 3: no number, only a limit; the forecaster's own chance of this, stated with the estimate: 30%; middle value at least 2.2-fold (0.34 log units) from the limit.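

Compound 3 gives only a limit, > 100000 nM. In this assay, benzyl(methyl)amino in place of (4-bromophenyl)amino gives an at least 2.6-fold higher number from compound 2 to compound 3 (0.43 log units; beyond the scatter), so a six-membered aromatic ring of carbon alone in the group at this position does not keep a definite number. Compound 1 and compound 3 both give limits, so the step between them cannot be read, and compound 2 remains the only compound with a definite number: the limit of > 100000 nM in this assay, at which 2 of the 3 values shown sit.

Open, going by these compounds, is whether phenylamino without the bromine, or benzylamino without the methyl, would give a definite number. Either group would help separate the parts of this exchange, which changes several things at once.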